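A few compounds are considered here, and "the series" means these few. Any claim that something is new, unique, unknown or untested is made for them only; others in the source may bear on it.

Compound 1 `CC(C)=CCC/C=C(\C)Cc1c(O)cc(O)c2c(=O)cc(-c3ccccc3)oc12` and compound 3 `CC(C)=CCC/C=C(\C)Cc1c(OC/C=C(\C)CCC=C(C)C)cc(O)c2c(=O)cc(-c3ccccc3)oc12` share one core; compound 2 `CC(C)=CCC/C=C(\C)Cc1c(O)cc(O)c2c(=O)c(OC/C=C(\C)CCC=C(C)C)c(-c3ccc(O)cc3)oc12` and compound 4 `CC(C)=CCC/C=C(\C)Cc1c(O)cc(O)c2c(=O)c(O)c(-c3ccc(O)cc3)oc12` share another, and the difference between the two cores is not broken down here. In a functional assay on HT-29 cells (Homo sapiens) for cytotoxicity, read by XTT assay, with a stated time of 72 h (on this read-out lower numbers stand for stronger inhibition and higher numbers for weaker inhibition), compound 1 gives 32000 nM. Compound 3 reaches only > 100000 nM in this assay, which is a limit of the assay and not a number. The change hydrogen in place of 3,7-dimethylocta-2,6-dien-1-yl on an oxygen on an aromatic ring thus made the step of an at least 3.1-fold lower number from compound 3 to compound 1 (0.49 log units; beyond the scatter), known only as a bound because of the limit of > 100000 nM in this assay, at which 1 of the 3 values shown sits. Compound 2 gives 30000 nM in this assay, within the scatter of compound 1. Compound 4 arises by the same change, (hydrogen in place of 3,7-dimethylocta-2,6-dien-1-yl on an oxygen on an aromatic ring). Compound 4 is expected to take the step of a 3.0-fold lower number from compound 2 to compound 4 (0.48 log units; beyond the scatter), an expectation that rests on an at least 3.1-fold lower number from compound 3 to compound 1 (0.49 log units; beyond the scatter). Compound 4 is therefore estimated at 10000 nM in this assay, between 4000 nM and 30000 nM.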

Compound 4, half-maximal inhibitory concentration: 30000 nM
Compound 4: middle estimate off by 3.0-fold (0.48 log units), on the low side; measured number inside the range.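

In this assay, the change from (3,7-dimethylocta-2,6-dien-1-yl)oxy to hydroxy gives no change at the digits printed from compound 2 to compound 4 (within the scatter), so in this pair of cores the step does not carry over from one to the other: the same change on two cores in this assay, an at least 3.1-fold lower number (0.49 log units; beyond the scatter) from compound 3 to compound 1 and no change at the digits printed (within the scatter) from compound 2 to compound 4, at least 3.1-fold (0.49 log units) apart, beyond the scatter of two such steps

On the core of compound 1, the size of the step stays open, and compound 3 stands at a limit of the assay and not a number: the limit of > 100000 nM in this assay, at which 1 of the 4 values shown sits.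

Two pairs show only that the outcome of this change can depend on the core; they give no cause and no rule for other cores in the series.

Open, on these data alone, is what a methyl group or a shorter chain in place of the 3,7-dimethylocta-2,6-dien-1-yl chain would give on either core. As far as these compounds go, a carboxylic acid or an amine at the end of such a chain also remains open.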